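The compounds below may be only part of what the source reports. "The series", "measured", "known", "first", "only" and "open" are said of these compounds alone.

Compound 1 `Cc1ccccc1NNC(=O)c1ccc(NS(=O)(=O)c2cnc(O)nc2O)cc1`: > 20000 nM
Compound 2 `Cc1cccc(NNC(=O)c2ccc(NS(=O)(=O)c3cnc(O)nc3O)cc2)c1`: > 20000 nM

In a functional assay on MDA-MB-231 cells (Homo sapiens) for antiproliferative activity, read by MTT assay, with a stated time of 24 h (a higher number here means a weaker inhibitor, a lower number a stronger inhibitor), compound 2 gives > 20000 nM, which is a limit and not a number. The measured compounds share this position: the limit of > 20000 nM in this assay, at which 2 of the 2 values shown sit. Compound 3 `O=C(NNc1ccccc1Cl)c1ccc(NS(=O)(=O)c2cnc(O)nc2O)cc1` carries 2-chlorophenyl in place of 3-methylphenyl on an amine nitrogen. For the measured compounds named here, the only measured step that bears on this change is a step that the two limits leave unreadable from compound 1 to compound 2, so it offers no size to carry over. No clear step is therefore expected in this assay, and another limit is the likeliest result. The expected step is a step that the limit leaves unreadable from compound 2 to compound 3. For compound 3 the estimate is 25000 nM, with an expected range of 12000 nM to 60000 nM.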

Compound 3, half-maximal inhibitory concentration: 4010 nM
Compound 3: middle estimate off by 6.2-fold (0.79 log units), on the high side; the whole stated range lies above it.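

In this assay, this position no longer looks flat: chloro gives the first readable value, with an at least 4.9-fold lower number from compound 2 to compound 3 (0.69 log units; beyond the scatter). The comparison with the matching 2-methylphenyl compound gives an at least 4.9-fold lower number from compound 1 to compound 3 (0.69 log units; beyond the scatter), so with the ring position unchanged, swapping methyl for chloro is enough to bring activity into range. Both steps are minimum sizes, since the other compounds remain at a limit rather than a number: the limit of > 20000 nM in this assay, at which 2 of the 3 values shown sit.

Going by these compounds, it remains open whether a fluoro, bromo or methoxy group would serve as chloro does here. It is also unclear whether the chloro must stay where it sits in 2-chlorophenyl.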